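The source may hold more compounds than are shown below. What is called first, only, known or untested is meant among the compounds shown, and "the series" means these compounds.

Measured compounds: compound 1 `COc1cc2nc(N3CCN(S(=O)(=O)c4ccc(Br)cc4)CC3)nc(N)c2cc1OC` gives 20000 nM in a functional assay on PC-3 cells (Homo sapiens) for inhibition; on this read-out higher numbers stand for weaker inhibition and lower numbers for stronger inhibition; compound 2 `COc1cc2nc(N3CCN(S(=O)(=O)c4ccc(C)cc4)CC3)nc(N)c2cc1OC` gives 30000 nM.

The two numbers lie within the scatter of each other, since the step of a 1.5-fold higher number from compound 1 to compound 2 (0.18 log units; within the scatter) is small. Compound 3 `COc1ccc(S(=O)(=O)N2CCN(c3nc(N)c4cc(OC)c(OC)cc4n3)CC2)cc1` differs from compound 2 by methoxy in place of methyl on an aromatic carbon. For the measured compounds named here, the only measured step that bears on it, from compound 1 to compound 2, also swapped the group on that aromatic carbon and stayed within the scatter, so no change beyond the scatter is expected for compound 3, giving an expected step of no change at the digits printed from compound 2 to compound 3 (within the scatter). Compound 3 is therefore estimated at 30000 nM, expected to fall between 12000 nM and 70000 nM.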

Compound 3, half-maximal inhibitory concentration: 39000 nM
Compound 3: the middle estimate sits 1.3-fold (0.11 log units) below what was measured, and the stated range covers the measured number.
By their numbers in this assay, from the lowest: compounds 1, 2 and 3 (each within the scatter of the next).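

At this aromatic carbon, para to a large group, methoxy adds an oxygen and a hydrogen-bond acceptor, yet in this assay the swap from methyl gives a 1.3-fold higher number from compound 2 to compound 3 (0.11 log units; within the scatter) and the swap from bromo gives a 2.0-fold higher number from compound 1 to compound 3 (0.29 log units; within the scatter). Bromo, methyl and methoxy thus all lie within the scatter of one another, which the single earlier step could not show. Nothing available gives a reason for this result. On these data alone, whether an amine, a carboxylic acid or a longer chain at this carbon would move the number beyond the scatter stays open.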